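A few compounds are considered here, and "the series" means these few. Any claim that something is new, unique, unknown or untested is made for them only; others in the source may bear on it.

Measured in a functional assay on BT-483 cells (Homo sapiens) for cytotoxicity, read by MTT assay, with a stated time of 24 h; on this read-out lower numbers stand for stronger inhibition and higher numbers for weaker inhibition:
- Compound 1 `CCNc1cc(-c2ccc(NC(=O)Nc3ccccc3Cl)cc2C(F)(F)F)ccn1`: 20800 nM
- Compound 2 `CCNc1cc(-c2ccc(NC(=O)Nc3c(C)cccc3C)cc2OC)ccn1`: > 30000 nM (a limit of the assay, not a number)

Compound 2 gives no number in this assay. Its > 30000 nM is a limit, and the evidence so far amounts to the limit of > 30000 nM in this assay, at which 1 of the 2 values shown sits.

Compound 3 `CCNc1cc(-c2ccc(NC(=O)Nc3ccccc3Cl)cc2OC)ccn1` keeps the rest of compound 2 but carries 2-chlorophenyl in place of 2,6-dimethylphenyl on an amide-type nitrogen. Among the measured compounds shown here, no measured pair isolates this change, so the guide is thin. For the measured compounds named here, the only support is compound 1, which also carries 2-chlorophenyl and gives 20800 nM.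

A small expected step toward stronger inhibition is the working assumption, an at least 1.2-fold lower number from compound 2 to compound 3 (0.07 log units; that floor lies within the scatter), and it may not clear the usual scatter. The estimated value for compound 3 is 25000 nM, with an expected range of 12000 nM to 45000 nM.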

Compound 3, half-maximal inhibitory concentration: > 30000 nM
Compound 3: no number, only a limit (the forecaster's own chance of this, stated with the estimate: 40%); at least 1.2-fold (0.07 log units) between middle value and limit.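

Compound 3 gives only a limit of the assay in this assay, and compound 2 gives a limit as well, so the change from 2,6-dimethylphenyl to 2-chlorophenyl on an amide-type nitrogen cannot be read: the limit of > 30000 nM in this assay, at which 2 of the 3 values shown sit.

The readable comparison lies at the other changed place, where 2-chlorophenyl stays fixed and methoxy in place of trifluoromethyl on an aromatic carbon gives an at least 1.4-fold higher number from compound 1 to compound 3 (0.15 log units; that floor lies within the scatter) as the lower bound of the shift. Of the compounds shown, only compound 1 gives a number, so 2-chlorophenyl alone does not bring a compound inside the limit.

Open, going by these compounds, is how 2-chlorophenyl and 2,6-dimethylphenyl compare when both carry trifluoromethyl, which would turn the unreadable change into a possible comparison. Also open, on these data alone, is whether a nitrile or a dimethylamino group on that aromatic carbon would give a number.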